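One Change Made Twice on Two Related Cores

The source may hold more compounds than are shown below. What is called first, only, known or untested is meant among the compounds shown, and "the series" means these compounds.

Compound 1 `COc1ccc(/C=C/C(=O)c2ccc(OCC3CO3)cc2)cc1` and compound 2 `COc1ccc(C(=O)/C=C/c2ccc(OCC3CO3)cc2)cc1` are built from the same atoms joined differently; how their two cores differ is not broken down here. In a functional assay on K562 cells (Homo sapiens) for cytotoxicity, read by MTT assay (a lower number here means a stronger inhibitor, a higher number a weaker inhibitor), compound 1 gives 28000 nM, and compound 2 gives 33500 nM, the two values lying within the scatter of each other. Compound 3 `COc1ccc(C(=O)/C=C/c2ccc(OCC(O)CCl)cc2)cc1` is compound 2 with one change, (2-chloro-1-hydroxyethyl in place of oxiran-2-yl on a saturated chain carbon bound to an oxygen on an aromatic ring), and in this assay compound 3 gives 29100 nM, so the step of a 1.2-fold lower number from compound 2 to compound 3 (0.06 log units; within the scatter) is within the scatter. Compound 4 `COc1ccc(/C=C/C(=O)c2ccc(OCC(O)CCl)cc2)cc1` carries the same change on the core of compound 1, (2-chloro-1-hydroxyethyl in place of oxiran-2-yl on a saturated chain carbon bound to an oxygen on an aromatic ring), at a place described in the same words, which makes it the same kind of change made on a different core. Within the data shown here, with only one measured example of this change, the expectation for compound 4 rests on that single step. Compound 4 is expected to follow suit, by an estimated 1.1-fold lower number from compound 1 to compound 4 (0.05 log units; within the scatter), because the measured step of a 1.2-fold lower number from compound 2 to compound 3 (0.06 log units; within the scatter) stayed within the scatter. In this assay compound 4 is therefore estimated at 25000 nM, most likely between 12000 nM and 50000 nM.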

Compound 4, half-maximal inhibitory concentration: 16200 nM
Estimate against measurement, compound 4: 1.5-fold (0.19 log units) above; low and high end bracket the measured number.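

On the core of compound 1, 2-chloro-1-hydroxyethyl in place of oxiran-2-yl gives a 1.7-fold lower number from compound 1 to compound 4 (0.24 log units; within the scatter) in this assay and so matches the earlier step on the other core. Neither step, nor the gap between them, stands clear of the scatter: the same change on two cores in this assay, a 1.2-fold lower number (0.06 log units; within the scatter) from compound 2 to compound 3 and a 1.7-fold lower number (0.24 log units; within the scatter) from compound 1 to compound 4, 1.5-fold (0.18 log units) apart, within the scatter of two such steps. This shows that across these two pairs the change carries from one core to the other without any separable difference, but it does not show that the change moves the number on either core, and two pairs set no rule for other cores in the series.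

The compounds shown leave open how a different group at this place, such as an amine or a longer chain in place of 3-chloro-2-hydroxypropyl, would read. They also leave open whether the two pairs would still agree outside this assay on any other read-out.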